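Swapping a halogen on the weakest of three inhibitors

The source may report more compounds than this note shows. Statements on the series, on what has been measured and on what is new or still open speak of the compounds shown alone.

Measured compounds:
- Compound 1 `C=CCn1c(=O)/c(=C\c2ccccc2Cl)[nH]c(=O)/c1=C\c1ccccc1OC`: 6400 nM
- Compound 2 `COc1ccccc1/C=c1/[nH]c(=O)/c(=C\c2nc[nH]c2C(C)(C)C)[nH]c1=O`: 90 nM
- Compound 3 `COc1ccccc1/C=c1\c(=O)[nH]/c(=C/c2ccccc2Cl)c(=O)n1C`: 300 nM

In a functional assay on Huh-7 cells (Homo sapiens) for cytotoxicity, read by CCK-8 assay, with a stated time of 72 h (on this read-out higher numbers stand for weaker inhibition and lower numbers for stronger inhibition), compound 1 gives the highest of the three numbers, so it is the weakest inhibitor here. Its nearest neighbour is compound 3, reached by a 21-fold lower number from compound 1 to compound 3 (1.33 log units; beyond the scatter), a change of hydrogen in place of vinyl on a saturated chain carbon bound to an aromatic nitrogen; compound 2 lies furthest away.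

Compound 4 `C=CCn1c(=O)/c(=C\c2ccccc2F)[nH]c(=O)/c1=C\c1ccccc1OC` is the unmeasured analogue. It differs from compound 1 by fluoro in place of chloro on an aromatic carbon; read one bond further out, a 2-chlorophenyl becomes a 2-fluorophenyl. Within the data shown here, no measured pair shows this exchange: the only recorded step changes the group on the nitrogen, not the halogen on the ring, so it says nothing about what fluoro in place of chloro does. Without a comparable precedent, the expected step of no change at the digits printed from compound 1 to compound 4 (within the scatter) is none beyond the scatter. Compound 4 is therefore estimated at 6400 nM, in a range from 2000 nM to 20000 nM.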

Compound 4, half-maximal inhibitory concentration: 31300 nM
Estimate against measurement, compound 4: 4.9-fold (0.69 log units) below, and the stated range ends below it.
By their numbers in this assay, from the lowest: compound 2; then compound 3; then compound 1; then compound 4.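

Among these compounds, until now, the only recorded step changed the group on the nitrogen; this result shows that the halogen on the aromatic ring also counts in this assay. Exchanging one halogen atom for another leaves the counts of heavy atoms, hydrogen-bond donors and hydrogen-bond acceptors unchanged, yet it gives a 4.9-fold higher number from compound 1 to compound 4 (0.69 log units; beyond the scatter) and so weakens inhibition beyond the scatter. At this place, with the rest of compound 1 kept, a 2-chlorophenyl therefore serves better than a 2-fluorophenyl.

On these data alone, whether bromo or a methyl group at the same ring carbon would strengthen inhibition further stays open, as does whether fluoro in place of chloro would do the same to compound 3. Nothing among the data shown gives a reason for this step.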